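Hydroxy in place of hydrogen on the core of compound 2

This account rests on a few compounds, and the source may have more. Where it says the series, first, only, none or still open, it means among the compounds named here.

Compound 1: `Cc1c(O)c(C(=O)NCC(=O)O)c(=O)n(Cc2ccccc2)c1C` — > 10000 nM
Compound 2: `O=C(O)CNC(=O)c1c(O)c(C(=O)NCc2ccccc2)cn(Cc2ccccc2)c1=O` — 1 nM

Among the measured compounds shown here, in an assay on Hep 3B2 cells for inhibition of prolyl hydroxylase EGLN3 (Homo sapiens), read by ELISA, with a stated time of 48 h (on this read-out lower numbers stand for an effect already at smaller amounts and higher numbers for an effect only at larger amounts of compound), compound 2 gives 1 nM, the only number in this set. For compound 1 the result of > 10000 nM is a limit of the assay, not a number. Compound 3, `O=C(O)CNC(=O)c1c(O)c(C(=O)NCc2ccccc2)c(O)n(Cc2ccccc2)c1=O`, carries hydroxy in place of hydrogen on an aromatic carbon relative to compound 2. For the measured compounds named here, no measured pair isolates this change, so its size is unknown from the data; a step within the scatter or a small loss is expected, written as a 4.0-fold higher number from compound 2 to compound 3 (0.60 log units; beyond the scatter). Compound 3 is therefore expected at 4 nM, with a range from 1 nM to 40 nM.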

Compound 3, half-maximal effective concentration: 1 nM
Estimate against measurement, compound 3: 4.0-fold (0.60 log units) above, and the stated range covers the measured number.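

In this assay hydroxy in place of hydrogen gives no change at the digits printed from compound 2 to compound 3 (within the scatter), so this aromatic carbon next to the ring nitrogen accepts a hydroxy group without a measurable shift. Among the compounds shown here, the earlier compounds offered no step at this position, and this pair is the first reading of it. Nothing measured here gives a reason for this result.

Still open, from the compounds shown here alone, is whether a methoxy group, an amine or a carboxylic acid on this carbon would be accepted as well. Also open, going by these compounds, is how a hydroxy group here behaves when the benzylcarbamoyl group is replaced by a shorter amide.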